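Compound 3: a Methoxy Group Enters the Core of Compound 1

This account rests on a few compounds, and the source may have more. Where it says the series, first, only, none or still open, it means among the compounds named here.

Measured so far:
Compound 1, `CN1C/C(=C\c2ccccc2)C(=O)[C@]2(C1)[C@@H](c1ccccc1)CN(C)[C@@]21C(=O)Nc2ccccc21`: 77%
Compound 2, `CN1C/C(=C\c2ccccc2)C(=O)[C@]2(C1)[C@@H](c1ccccc1)CN(C)[C@@]21C(=O)N(C)c2ccccc21`: 68%

Going by the values given here, in a functional assay on the whole organism (strain Wister albino) for inhibition, with Rattus norvegicus as the target, read by paw edema, with a stated time of 1 h, at a dose of 50 mg/kg by the intraperitoneal route (on this read-out lower numbers stand for less inhibition and higher numbers for more inhibition at the one dose given (going by the name of the read-out)), compound 1 holds the highest of the two numbers, yet its only neighbour, compound 2, lies within the scatter of it, so no order between them can be claimed. Among the compounds with values here, the single measured step, a number 9 percentage points lower from compound 1 to compound 2 (within the scatter), concerns methyl in place of hydrogen on an amide-type nitrogen in a ring and leaves the aromatic rings untouched.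

Compound 3, `COc1ccc(/C=C2\CN(C)C[C@@]3(C2=O)[C@@H](c2ccccc2)CN(C)[C@@]32C(=O)Nc3ccccc32)cc1`, differs from compound 1 by methoxy in place of hydrogen on an aromatic carbon; cut one bond further out, the change reads phenyl to 4-methoxyphenyl. Within the data shown here, no measured step touches this site, so nothing among the known values argues for a move beyond the scatter. Compound 3 is therefore expected to sit close to compound 1, with an estimated step of a number 2 percentage points lower from compound 1 to compound 3 (within the scatter). The estimate for compound 3 in this assay is 75%, within a range from 60% to 90%.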

Compound 3, a percentage reported as inhibition, in the whole organism at one dose (the size of the read-out at that dose, not a potency): 80.1%
For compound 3 the middle estimate is 5.1 percentage points below the measured one; the measured number falls inside the stated range.
By their numbers in this assay, from the lowest: compounds 2, 1 and 3 (each within the scatter of the next, the first and the last beyond it).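

In this assay, going by these compounds alone, the change from phenyl to 4-methoxyphenyl gives the first reading at this site, a number 3.1 percentage points higher from compound 1 to compound 3 (within the scatter), so compound 3 cannot be told apart from compound 1. The earlier step spoke only to the amide-type nitrogen, whereas this one shows that a six-membered aromatic ring of the shared core can carry methoxy without a difference beyond the usual scatter of this read-out. No available evidence bears on the result.

As far as these compounds go, whether this holds for other groups at the same place, such as an amine, a carboxylic acid or a longer alkoxy chain, remains open. Also open, from the compounds shown here alone, is whether methoxy on a different aromatic carbon would read the same, and the single dose gives no measure of potency.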